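This account rests on a few compounds, and the source may have more. Where it says the series, first, only, none or still open, it means among the compounds named here.

Measured in an ADME assay on BJ cells (Homo sapiens) for cytotoxicity, read by MTT assay, with a stated time of 72 h; a higher number here means a weaker inhibitor, a lower number a stronger inhibitor:
- Compound 1 `COc1ccc(CNc2ncnc3c2ncn3C2CCCO2)cc1OC`: > 100000 nM
- Compound 2 `COc1cc(CNc2ncnc3c2ncn3C2CCCO2)cc(OC)c1`: > 100000 nM

Compound 2 stands at the limit of > 100000 nM in this assay, at which 2 of the 2 values shown sit, and this is a limit of the assay, not a number. Compound 3 `COc1cc(CNc2ncnc3c2ncn3C2CCCO2)cc(OC)c1OC` has methoxy in place of hydrogen on an aromatic carbon, ortho to two methoxy groups and para to a large group: methoxy in place of hydrogen on an aromatic carbon. Within the data shown here, no measured step shows what such a change does, so in this assay no change beyond the usual scatter is expected. The estimated size of the step is a number no higher from compound 2 to compound 3 (the limit leaves the size open). For compound 3 the expected value is 100000 nM, within an estimated range of 40000 nM to 150000 nM.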

Compound 3, half-maximal inhibitory concentration: > 100000 nM
Compound 3: no number, only a limit; the forecaster's own chance of this, stated with the estimate: 80%; the middle value sits exactly at the limit.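

No step can be read from compound 1 or compound 2 to compound 3, because each value is a limit of the assay, not a number: the limit of > 100000 nM in this assay, at which 3 of the 3 values shown sit.

On these data alone, what methoxy in place of hydrogen does in this assay stays open.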